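The compounds below may be only part of what the source reports. "The series", "measured", "known", "first", "only" and "open" are said of these compounds alone.

Measured compounds in a toxicity assay on THP-1 cells (Homo sapiens) for inhibition; on this read-out higher numbers stand for lower toxicity in this test and lower numbers for higher toxicity in this test:

Compound 1, `Cc1ccccc1C(=O)Nc1ncc(-c2ccccc2)n1C`, gives > 100000 nM, which is a limit of the test and not a number.
Compound 2, `Cn1c(-c2ccccc2)cnc1NC(=O)c1ccccc1`, gives > 100000 nM, again a limit rather than a number.
Compound 3, `COc1ccc(-c2cnc(NC(=O)c3ccc(C)cc3)n2C)cc1`, gives > 100000 nM, also a limit and not a number.

Going by the values given here, the one step that can be paired is a step that the two limits leave unreadable from compound 1 to compound 2. Its structural content is hydrogen in place of methyl on an aromatic carbon. Among the compounds with values here, both ends of that step sit at the same limit, and the limit of > 100000 nM in this assay, at which 3 of the 3 values shown sit, is the only evidence on hand: all three values shown rest there, so the size of the step cannot be read.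

Compound 4, `COc1ccc(-c2cnc(NC(=O)c3ccccc3)n2C)cc1`, has not yet been tested. It differs from compound 3 by hydrogen in place of methyl on an aromatic carbon. This is the same kind of change as that between compound 1 and compound 2, but not the same: in the earlier pair the methyl sits ortho to a large group, here it sits para to a large group. The difference between the core of compound 1 and the core of compound 3 is not broken down here.

In this assay compound 4 is expected to show a step that the limit leaves unreadable from compound 3 to compound 4, which rests on compound 3 giving only the limit > 100000 nM and on the limit of > 100000 nM in this assay, at which 3 of the 3 values shown sit, placing every measured value at that same limit. Compound 4 is therefore estimated at 150000 nM, with a range from 80000 nM to 400000 nM, and most likely again only a limit will be reported.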

Compound 4, half-maximal cytotoxic concentration: > 100000 nM
Compound 4: a limit, no number; the forecaster's own chance of this, stated with the estimate: 85%; the middle value lies beyond the limit too.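

In this assay compound 4 gives > 100000 nM as a limit and not a number. No new step can be read from compound 3 to compound 4 or from compound 2 to compound 4, because all the values rest at one limit: the limit of > 100000 nM in this assay, at which 4 of the 4 values shown sit.

The compounds shown leave open how large these changes are and whether this assay can give a number for any compound of this kind.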